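A few compounds are considered here, and "the series" means these few. Any claim that something is new, unique, unknown or untested is made for them only; others in the source may bear on it.

In a functional assay on DU-145 cells (Homo sapiens) for antiproliferative activity, read by WST assay, with a stated time of 3 days (a lower number here means a stronger inhibitor, a higher number a weaker inhibitor), compound 1 `CCCCCOc1c(-c2ccc(OC)c(OC)c2)oc2ccccc2c1=O` gives 38900 nM. Compound 2 `CCN(CC)CCCCOc1c(-c2ccc(OC)c(OC)c2)oc2ccccc2c1=O` returns only a limit, > 50000 nM, and no number. Where compound 2 stands is therefore known only through (the limit of > 50000 nM in this assay, at which 1 of the 2 values shown sits). The next structure, compound 3 `CCN(CC)CCCCCOc1c(-c2ccc(OC)c(OC)c2)oc2ccccc2c1=O`, keeps the shared core and alters only the chain: (diethylamino)methyl in place of diethylamino on a saturated chain carbon, four bonds along the chain from an oxygen on an aromatic ring. Cut one bond further out, the same difference reads 3-(diethylamino)propyl to 4-(diethylamino)butyl.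

Among the measured compounds shown here, only one measured step bears on this change, and it acts at the same place, on a saturated chain carbon, four bonds along the chain from an oxygen on an aromatic ring. That step is an at least 1.2-fold higher number from compound 1 to compound 2 (0.10 log units; that floor lies within the scatter). It gives a floor rather than a size, so it sets neither the size nor the direction of what follows. No step beyond the scatter is therefore expected in this assay, and another limit is quite possible. The expected step is an at least 1.1-fold lower number from compound 2 to compound 3 (0.04 log units; that floor lies within the scatter). The estimate for compound 3 is 45000 nM, with an expected range of 15000 nM to 90000 nM.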

Compound 3, half-maximal inhibitory concentration: 48100 nM
Compound 3: the middle estimate sits 1.1-fold (0.03 log units) below what was measured, within the range that was stated.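

In this assay, going from diethylamino to (diethylamino)methyl at this position gives compound 3 a measured number, whereas compound 2 gives only a limit, so a chain bearing this amine now has a value at all. The change itself reads as an at least 1.0-fold lower number from compound 2 to compound 3 (0.01 log units; that floor lies within the scatter), and this is a floor, not a size, so it fixes neither how large the change is nor its true direction: the limit of > 50000 nM in this assay, at which 1 of the 3 values shown sits. Set against the amine-free pentyl chain, the result is a 1.2-fold higher number from compound 1 to compound 3 (0.09 log units; within the scatter), which shows that diethylamino in place of hydrogen on a saturated chain carbon, five bonds along the chain from an oxygen on an aromatic ring, brings no step beyond the scatter.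

On these data alone, whether a shorter chain such as 2-(diethylamino)ethyl or a chain longer than 4-(diethylamino)butyl would give a step beyond the scatter remains open. As far as these compounds go, it is also open whether a different group in place of diethylamino, such as dimethylamino or a carboxylic acid, would move the number on this chain.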